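Adding methoxy to the phenylsulfonyl group of compound 3

This account rests on a few compounds, and the source may have more. Where it says the series, first, only, none or still open, it means among the compounds named here.

In an ADME assay on HEK-293T cells (Homo sapiens) for cytotoxicity, read by MTT assay, with a stated time of 24 h (on this read-out higher numbers stand for lower toxicity in this test and lower numbers for higher toxicity in this test), compound 1 (`Cc1ccc(-c2nn(-c3ccccc3)cc2-c2nc3ccccc3n2S(=O)(=O)c2ccccc2)cc1`) gives 138000 nM, compound 2 (`Cc1ccc(-c2nn(-c3ccccc3)cc2-c2nc3ccccc3n2S(=O)(=O)c2ccc(C(F)(F)F)cc2)cc1`) gives 182000 nM, and compound 3 (`O=S(=O)(c1ccccc1)n1c(-c2cn(-c3ccccc3)nc2-c2ccc(F)cc2)nc2ccccc21`) gives 96300 nM. Compound 3 thus stands within the scatter of both other compounds, so the three cannot be ranked on these numbers. The next compound, compound 4 (`COc1ccc(S(=O)(=O)n2c(-c3cn(-c4ccccc4)nc3-c3ccc(F)cc3)nc3ccccc32)cc1`), has methoxy in place of hydrogen on an aromatic carbon of the phenylsulfonyl group, para to a large group: methoxy in place of hydrogen on an aromatic carbon. Among the measured compounds shown here, no methoxy compound has been measured yet. For the measured compounds named here, the nearest precedent is a 1.3-fold higher number from compound 1 to compound 2 (0.12 log units; within the scatter), where trifluoromethyl replaces hydrogen on an aromatic carbon. The other available change, fluoro in place of methyl, is a 1.4-fold lower number from compound 1 to compound 3 (0.16 log units; within the scatter) and bears on the question less directly. Both steps are small, and neither goes beyond the scatter, so no shift beyond the scatter is expected in this assay. The expected change is a 1.1-fold higher number from compound 3 to compound 4 (0.06 log units; within the scatter), which is no more than a tentative lean. For compound 4 the estimated value is 110000 nM, with an expected range from 60000 nM to 200000 nM.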

Compound 4, half-maximal cytotoxic concentration: 37300 nM
The estimate for compound 4 lay 2.9-fold (0.47 log units) above the measured number; measured number below the stated range.
By their numbers in this assay, from the lowest: compound 4; then compounds 3, 1 and 2 (each within the scatter of the next).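

In this assay, the phenylsulfonyl group turns out to be a place where a single substitution can move the number beyond the scatter: methoxy in place of hydrogen, para to a large group, gives a 2.6-fold lower number from compound 3 to compound 4 (0.41 log units; beyond the scatter). The earlier change on that group, trifluoromethyl in place of hydrogen, gave only a 1.3-fold higher number from compound 1 to compound 2 (0.12 log units; within the scatter), so the outcome depends either on the entering group or on the rest of the molecule, which carries fluoro in compound 4 and methyl in compound 2. Nothing available explains the shift.

The compounds shown leave open whether methoxy would lower the number in the same way on the methyl-bearing compound 1. They also leave open whether an ethoxy group, a hydroxyl or an amine at this position would follow methoxy.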